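A few compounds are considered here, and "the series" means these few. Any claim that something is new, unique, unknown or untested is made for them only; others in the source may bear on it.

Measured compounds:

Compound 1, `O=c1[nH]nc2n(c1=O)CCN2c1ccccc1`, gives 7% in an ADME assay on Vero cells (Chlorocebus sabaeus) for cytotoxicity, with a stated time of 72 h, tested at 10 ug/mL; on this read-out higher numbers stand for a stronger effect at the one concentration tested and lower numbers for a weaker effect.
Compound 2, `N=c1c(=O)[nH]nc2n1CCN2c1cccc(Cl)c1`, gives 0% in this assay.
Compound 3, `N=c1c(=O)[nH]nc2n1CCN2c1ccccc1`, gives 26% in this assay.

Compounds 2 and 3 share one core and differ in a single place: chloro in place of hydrogen on an aromatic carbon. That change went with a number 26 percentage points lower from compound 3 to compound 2 (beyond the scatter). Compound 1 has a different core; the difference between the two cores is not broken down here. Against compounds 2 and 3, compound 1 sits in the middle: its value and that of compound 2 are within the scatter of each other, while compound 3 stands beyond the scatter above it.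

Compound 4, `O=c1[nH]nc2n(c1=O)CCN2c1cccc(Cl)c1`, is not yet measured. It stands to compound 1 exactly as compound 2 stands to compound 3: chloro in place of hydrogen on an aromatic carbon. The description of where the chloro enters is the same, word for word, in both pairs, so this is the same change made on the other core.

Among the compounds with values here, the one measured example of this change lowered the read-out, and compound 1 already starts low. Because compound 1 gives 7%, there is little room left for a fall of the size seen from compound 3 to compound 2, and a read-out cannot go below nothing. The expected step is therefore small: compound 4 is estimated to land a number 5 percentage points lower from compound 1 to compound 4 (within the scatter) from compound 1. Compound 4 is expected to give about 2%, with a likely range from 0% to 12%.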

Compound 4, a percentage reported as inhibition, at one concentration (the size of the read-out at that concentration, not a potency): 11%
Compound 4: middle estimate off by 9 percentage points, on the low side; measured number inside the range.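

On the core of compound 1, chloro in place of hydrogen on an aromatic carbon goes with a number 4 percentage points higher from compound 1 to compound 4 (within the scatter) in this assay. Within the data shown here, in this series, then, the change did not carry over from one core to the other with the same size of step, so the step seen on one core would have been a poor guide to the step on the other: the same change on two cores in this assay, a number 26 percentage points lower (beyond the scatter) from compound 3 to compound 2 and a number 4 percentage points higher (within the scatter) from compound 1 to compound 4, 30 percentage points apart, beyond the scatter of two such steps This does not show why the two steps part, and with only one pair on each core it gives no rule for how chloro would behave on a further core, or whether repeat measurements of each pair would give the same picture.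

The compounds shown carry only hydrogen or chloro on the aromatic ring, and chloro stands in one place only, meta to a large group, so it remains open what chloro elsewhere on that ring would do on either core. On these data alone, it also remains open whether other groups at that place, such as a methoxy group, an amine or a carboxylic acid, would give steps that agree between the two cores or part as these do.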